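Bromo in Place of Fluoro on Two Related Cores

A few compounds are considered here, and "the series" means these few. Any claim that something is new, unique, unknown or untested is made for them only; others in the source may bear on it.

Measured so far:
compound 1, `O=S(=O)(/C=C/c1ccc(F)cc1)Cc1ccc(Nc2ncnc3ccccc23)cc1`: 10 nM
compound 2, `O=S(=O)(/C=C/c1ccc(Br)cc1)Cc1ccc(Nc2ncnc3ccccc23)cc1`: 200 nM
compound 3, `COc1cc2ncnc(Nc3ccc(CS(=O)(=O)/C=C/c4ccc(F)cc4)cc3)c2cc1OC`: a limit, > 100000 nM

In a functional assay on ACHN cells (Homo sapiens) (on this read-out higher numbers stand for weaker inhibition of growth and lower numbers for stronger inhibition of growth), compound 1 gives 10 nM. Compound 2 gives 200 nM in this assay. Between them lies one change, (bromo in place of fluoro on an aromatic carbon), and it made a step of a 20-fold higher number from compound 1 to compound 2 (1.30 log units; beyond the scatter). Compound 3 carries a different core; the difference between the two cores is not broken down here. For compound 3 this assay gives only a limit, > 100000 nM, which is the limit described as the limit of > 100000 nM in this assay, at which 1 of the 3 values shown sits.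

Compound 4, `COc1cc2ncnc(Nc3ccc(CS(=O)(=O)/C=C/c4ccc(Br)cc4)cc3)c2cc1OC`, has not yet been measured. It differs from compound 3 by bromo in place of fluoro on an aromatic carbon, the same change, at the same place, that separates compound 1 from compound 2.

The expectation for compound 4 rests on two things: compound 3 already sits at the limit of > 100000 nM, and the earlier step of a 20-fold higher number from compound 1 to compound 2 (1.30 log units; beyond the scatter) weakened growth inhibition. Compound 4 is therefore expected to stay at that limit, with an estimated step that the limit leaves unreadable from compound 3 to compound 4. The estimate for compound 4 in this assay is 300000 nM, from 100000 nM to 1000000 nM.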

Compound 4, concentration for 50% growth inhibition: 4000 nM
Estimate against measurement, compound 4: 75-fold (1.88 log units) above; measured number outside the range, below it.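

In this assay, bromo in place of fluoro on an aromatic carbon gave an at least 25-fold lower number from compound 3 to compound 4 (1.39 log units; beyond the scatter), a step in the opposite direction to the one seen with the same change on the core of compound 1: the same change on two cores in this assay, a 20-fold higher number (1.30 log units; beyond the scatter) from compound 1 to compound 2 and an at least 25-fold lower number (1.39 log units; beyond the scatter) from compound 3 to compound 4, at least 500-fold (2.69 log units) apart, beyond the scatter of two such steps The value of compound 3, > 100000 nM, is a limit of the assay and not a number, so the new step has only a lower bound on its size: the limit of > 100000 nM in this assay, at which 1 of the 4 values shown sits. Within these four compounds, the effect of this change did not carry over from one core to the other, but with a single pair on each core this does not show why the two cores differ or how any other change would behave.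

The compounds shown leave open whether chloro or a nitrile on that aromatic carbon would follow the fluoro or the bromo on either core. They also leave open which part of the difference between the two cores turns the step around.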